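The compounds below may be only part of what the source reports. "The series", "measured", "known", "first", "only" and "open" are said of these compounds alone.

Compound 1 `CCOc1nc(-c2cc3ccccc3o2)cc(-c2ccc(F)cc2)c1C#N` gives 396000 nM in a functional assay on aorta (strain Wistar) for inhibition, with Thoracic aorta (Rattus norvegicus) as the target; a lower number here means a stronger inhibitor, a higher number a weaker inhibitor. Compound 2 `CCOc1nc(-c2cc3ccccc3o2)cc(-c2ccc(OC)cc2OC)c1C#N` gives 488000 nM. Compound 3 `CCOc1nc(-c2cc3ccccc3o2)cc(-c2cc(OC)ccc2OC)c1C#N` gives 327000 nM.

All three share one core and differ only in the aromatic group carried on it. Compound 3 is not set apart from the other two: a 1.2-fold lower number from compound 1 to compound 3 (0.08 log units; within the scatter) and a 1.5-fold lower number from compound 2 to compound 3 (0.17 log units; within the scatter). Compound 1 and compound 2 are likewise not apart from each other: a 1.2-fold higher number from compound 1 to compound 2 (0.09 log units; within the scatter). Compound 4 `CCOc1nc(-c2cc3ccccc3o2)cc(-c2cccs2)c1C#N` alters that same place once more: thiophen-2-yl in place of 2,5-dimethoxyphenyl on an aromatic carbon. The measured steps that bear on this exchange are those that swap one aromatic group for another at this place, and none of them shifted the number beyond the scatter. A step of similar size, in no particular direction, is therefore expected: a 1.2-fold higher number from compound 3 to compound 4 (0.09 log units; within the scatter). Compound 4 is thus estimated at 400000 nM, with a range from 150000 nM to 1000000 nM.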

Compound 4, half-maximal inhibitory concentration: 308000 nM
For compound 4 the middle estimate is 1.3-fold (0.11 log units) above the measured one; the measured number falls inside the stated range.
By their numbers in this assay, from the lowest: compounds 4, 3, 1 and 2 (each within the scatter of the next).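

Thiophen-2-yl, a five-membered aromatic ring with 5 heavy atoms, stays within the scatter of all three larger six-membered aromatic groups in this assay (a 1.1-fold lower number from compound 3 to compound 4 (0.03 log units; within the scatter); a 1.6-fold lower number from compound 2 to compound 4 (0.20 log units; within the scatter); a 1.3-fold lower number from compound 1 to compound 4 (0.11 log units; within the scatter)). At this place, opposite the ring nitrogen, neither the smaller ring nor the sulfur atom moves the number beyond the scatter. No measurement shown gives a reason for this flat result. Every group shown here is aromatic, so an amine, a carboxylic acid or a longer chain at this place remains open. Changes to the ethoxy, cyano or 1-benzofuran-2-yl groups also remain open.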